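The source may hold more compounds than are shown below. What is called first, only, known or untested is meant among the compounds shown, and "the series" means these compounds.

Measured so far in an assay on RBL-1 cells for inhibition of Polyunsaturated fatty acid 5-lipoxygenase (Rattus norvegicus); on this read-out higher numbers stand for weaker inhibition and lower numbers for stronger inhibition: compound 1 `Cc1ccc(C(=O)/C=C/c2ccc(O)c(O)c2)cc1` gives 76 nM; compound 2 `Cc1ccc(C(=O)/C=C/c2ccc(O)c(O)c2)c(C)c1` gives 17 nM.

Among the compounds with values here, compound 2 stands lowest of the two numbers, and its only neighbour is compound 1, separated by a 4.5-fold lower number from compound 1 to compound 2 (0.65 log units; beyond the scatter). Compound 3 `Cc1cc(C)c(C(=O)/C=C/c2ccc(O)c(O)c2)c(C)c1` differs from compound 2 by methyl in place of hydrogen on an aromatic carbon. Within the data shown here, one measured step bears on this change, the modest one from compound 1 to compound 2, so a step of similar or smaller size toward a lower number is expected for compound 3 in this assay, namely a 1.7-fold lower number from compound 2 to compound 3 (0.23 log units; within the scatter). Compound 3 is therefore estimated at 10 nM, with a range from 4 nM to 35 nM.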

Compound 3, half-maximal inhibitory concentration: 400 nM
The estimate for compound 3 lay 40-fold (1.60 log units) below the measured number, and the stated range ends below it.
By their numbers in this assay, from the lowest: compound 2; then compound 1; then compound 3.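

In this assay, methyl in place of hydrogen on an aromatic carbon now runs the opposite way, with a 24-fold higher number from compound 2 to compound 3 (1.37 log units; beyond the scatter) set against a 4.5-fold lower number from compound 1 to compound 2 (0.65 log units; beyond the scatter) at the earlier place. The change therefore has no single direction across these compounds: ortho to a large group and meta to two methyl groups, it gives a higher number. Nothing measured here accounts for this reversal. Going by these compounds, whether a chlorine atom, a methoxy group or an amine at this place would also give a higher number remains open.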